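The source may hold more compounds than are shown below. What is called first, only, known or untested is meant among the compounds shown, and "the series" means these compounds.

Compounds sharing one core and differing only in the aryl group on an amide-type nitrogen have been tested in a functional assay on A549 cells (Homo sapiens) for cytotoxicity, read by MTT assay, with a stated time of 72 h; a higher number here means a weaker inhibitor, a lower number a stronger inhibitor. There, compound 1 `COc1ccc(NC(=O)CN2CCN(c3nnc(Cc4ccncc4)c4ccccc34)CC2)cc1OC` gives 26500 nM, compound 2 `O=C(CN1CCN(c2nnc(Cc3ccncc3)c3ccccc23)CC1)Nc1ccc(Br)cc1` gives 2710 nM, and compound 3 `O=C(CN1CCN(c2nnc(Cc3ccncc3)c3ccccc23)CC1)Nc1ccc(F)c(C(F)(F)F)c1` gives 16000 nM. Two steps place compound 3: a 1.7-fold lower number from compound 1 to compound 3 (0.22 log units; within the scatter), and a 5.9-fold higher number from compound 2 to compound 3 (0.77 log units; beyond the scatter). It therefore sits with compound 1, well clear of compound 2.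

Compound 4 `O=C(CN1CCN(c2nnc(Cc3ccncc3)c3ccccc23)CC1)Nc1c(F)cccc1F` has 2,6-difluorophenyl in place of 4-fluoro-3-(trifluoromethyl)phenyl on an amide-type nitrogen. Those two steps change the same place as this swap, and so does a 9.8-fold lower number from compound 1 to compound 2 (0.99 log units; beyond the scatter). Changes here can thus shift the number modestly or leave it within the scatter. Among the measured compounds shown here, none of the measured compounds carries 2,6-difluorophenyl, so the data give no direction, and no step beyond the scatter is expected in this assay. The expected step is a 1.3-fold lower number from compound 3 to compound 4 (0.12 log units; within the scatter). For compound 4 the estimated value is 12000 nM, with an expected range from 4000 nM to 32000 nM.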

Compound 4, half-maximal inhibitory concentration: 54400 nM
Estimate against measurement, compound 4: 4.5-fold (0.66 log units) below, and the stated range ends below it.
By their numbers in this assay, from the lowest: compound 2; then compounds 3 and 1 (each within the scatter of the next); then compound 4.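

In this assay, 2,6-difluorophenyl gives a 3.4-fold higher number from compound 3 to compound 4 (0.53 log units; beyond the scatter). It also gives a 2.1-fold higher number from compound 1 to compound 4 (0.31 log units; beyond the scatter) and a 20-fold higher number from compound 2 to compound 4 (1.30 log units; beyond the scatter), which makes compound 4 the weakest inhibitor of the four and shows that this position can span a large range of values, with the new group at the weak end. Fluorine on the ring does not settle the value by itself, since compound 3 and compound 4 both carry it and still stand apart, and nothing available here explains the loss.

Going by these compounds, what remains open is how a plain phenyl group, with no substituent at all, would compare on the same amide-type nitrogen. It is also unclear whether an aryl ring is needed there, or whether a simple alkyl chain ending in an amine or a carboxylic acid could take its place.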